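Swapping Chloro for Methyl on the Core of Compound 1

A few compounds are considered here, and "the series" means these few. Any claim that something is new, unique, unknown or untested is made for them only; others in the source may bear on it.

compound 1 `Cc1cc(C)nc(SCc2cc(=O)c3cc(Cl)ccc3o2)n1`: > 25000 nM
compound 2 `O=c1c(CSc2cc(=O)c3ccccc3s2)coc2ccccc12`: 2600 nM

Both compounds were tested in a functional assay on HeLa cells (Homo sapiens) for cytotoxicity, read by MTT assay, with a stated time of 72 h; on this read-out higher numbers stand for weaker inhibition and lower numbers for stronger inhibition. For compound 1 the result is only a limit of the assay, > 25000 nM, not a measured number. Compound 2, built on a different core, gives 2600 nM in this assay. Compound 1 thus stands at the limit of > 25000 nM in this assay, at which 1 of the 2 values shown sits, and since no single-point change links it to compound 2, the two values are simply shown side by side.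

Compound 3 `Cc1ccc2oc(CSc3nc(C)cc(C)n3)cc(=O)c2c1` is the unmeasured partner of compound 1: methyl in place of chloro on an aromatic carbon. Going by the values given here, no measured step of this kind is available. Expected is a step that the limit leaves unreadable from compound 1 to compound 3, nothing beyond the usual scatter. Compound 3 is therefore estimated at 30000 nM, with a range from 8000 nM to 100000 nM, and most likely again reported only as a limit.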

Compound 3, half-maximal inhibitory concentration: > 25000 nM
Compound 3: no number, only a limit; the forecaster's own chance of this, stated with the estimate: 75%; the middle value is on the limit's open side.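

Compound 1 and compound 3 each give only a limit of the assay, not a number, so no step between them can be read: the limit of > 25000 nM in this assay, at which 2 of the 3 values shown sit.

As far as these compounds go, whether methyl in place of chloro on an aromatic carbon changes the result in this assay at all, and in which direction, stays open.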